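This account rests on a few compounds, and the source may have more. Where it says the series, first, only, none or still open, it means among the compounds named here.

Measured so far:
compound 1, `CCN(CC)C(=S)SCC1=CCOC1=O`: 57100 nM
compound 2, `CN1CCN(C(=S)SCC2=CCOC2=O)CC1`: 40500 nM

In a functional assay on PC-3 cells (Homo sapiens) for antiproliferative activity, read by MTT assay, with a stated time of 72 h (on this read-out higher numbers stand for weaker inhibition and lower numbers for stronger inhibition), compound 1 gives 57100 nM and compound 2 gives 40500 nM. The two compounds share the core and differ only in the substituent on the thiocarbonyl-bearing nitrogen. Compound 1 carries the higher of the two numbers, but the gap to compound 2 is within the scatter, so the two results cannot be separated; both sit at the weak end of the read-out.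

Compound 3, `CCNC(=S)SCC1=CCOC1=O`, has not yet been measured. Relative to compound 1 the change is hydrogen in place of ethyl on an amide-type nitrogen, which read one bond further out is diethylamino to ethylamino. Going by the values given here, no measured pair shows this change, so its size is not known from the data. A step beyond the scatter is not expected, because compound 1 at 57100 nM and compound 2 at 40500 nM lie within the scatter of each other although their nitrogen substituents differ. Compound 3 is expected at 65000 nM, in the range 25000 nM to 170000 nM. The expected step is a 1.1-fold higher number from compound 1 to compound 3 (0.06 log units; within the scatter), within the scatter.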

Compound 3, half-maximal inhibitory concentration: 30600 nM
Compound 3: middle estimate off by 2.1-fold (0.33 log units), on the high side, and the stated range covers the measured number.
By their numbers in this assay, from the lowest: compounds 3, 2 and 1 (each within the scatter of the next).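

Going by these compounds alone, compound 3 gives the first direct reading at the amide-type nitrogen: in this assay, hydrogen in place of ethyl, which read one bond further out is diethylamino to ethylamino, gives a 1.9-fold lower number from compound 1 to compound 3 (0.27 log units; within the scatter). Compound 1 and compound 3 therefore cannot be separated, and the exchange of this ethyl for the amide hydrogen leaves no measurable mark on the read-out, a finding that rests on this single pair. No available measurement speaks to the reason for this result.

A single small exchange at this nitrogen leaves open whether a different kind of substituent there, such as a longer chain like n-hexyl, a benzyl group or a chain ending in a carboxylic acid, would produce a step beyond the scatter. On these data alone, it also remains open whether replacing the remaining ethyl of compound 3 with hydrogen, to leave an unsubstituted amino group, would separate from compound 3 in this assay.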